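Hydroxy in Place of Hydrogen on a Low-Toxicity Core

This account rests on a few compounds, and the source may have more. Where it says the series, first, only, none or still open, it means among the compounds named here.

Of the compounds shown here, three with a shared core have been tested in an ADME assay on HEK293 cells (Homo sapiens) for cytotoxicity, read by reporter gene assay and resazurin assay, with a stated time of 48 h; on this read-out higher numbers stand for lower toxicity in this test and lower numbers for higher toxicity in this test. Compound 1 `O=C(Nc1ccc(Sc2nc3ccccc3s2)cc1)c1cc(Br)cc(Br)c1O` gives 66000 nM in this assay. Compound 2 `COc1c(Br)cc(Br)cc1C(=O)Nc1ccc(Sc2nc3ccccc3s2)c(Cl)c1` reaches only the limit of this assay, reported as > 100000 nM. Compound 3 `O=C(Nc1ccc(Sc2nc3ccccc3s2)c(Cl)c1)c1cc(Br)cc(Br)c1` likewise reaches only the limit, reported as > 100000 nM. For the measured compounds named here, compound 3 thus stands at the top of the measured range without a number of its own, a position it shares with compound 2 (the limit of > 100000 nM in this assay, at which 2 of the 3 values shown sit), while compound 1 is the only compound with a definite number.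

Compound 4 `O=C(Nc1ccc(Sc2nc3ccccc3s2)c(Cl)c1)c1cc(Br)cc(Br)c1O` differs from compound 3 by hydroxy in place of hydrogen on an aromatic carbon. Going by the values given here, the single measured step that touches this comparison, a step that the two limits leave unreadable from compound 2 to compound 3, cannot be read in size because both ends sit at a limit. Compound 4 shares its 3,5-dibromo-2-hydroxyphenyl group with compound 1, which gives 66000 nM in this assay. Compound 4 is therefore expected to give about 70000 nM, between 30000 nM and 150000 nM, with a real chance that only a limit is reported. The expected step of an at least 1.4-fold lower number from compound 3 to compound 4 (0.15 log units; that floor lies within the scatter) is estimated to lie within the scatter.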

Compound 4, half-maximal cytotoxic concentration: 76000 nM
Beside the measured number, compound 4's estimate is 1.1-fold (0.04 log units) below it; the measured number falls inside the stated range.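

In this assay, hydroxy in place of hydrogen gives an at least 1.3-fold lower number from compound 3 to compound 4 (0.11 log units; that floor lies within the scatter), and hydrogen in place of methyl on the oxygen gives an at least 1.3-fold lower number from compound 2 to compound 4 (0.11 log units; that floor lies within the scatter); both floors lie within the scatter. For the compounds shown here, each of these two steps starts from a limit of the assay, so neither has a full size: the limit of > 100000 nM in this assay, at which 2 of the 4 values shown sit. The only step here between two real numbers is chloro in place of hydrogen, which gives a 1.2-fold higher number from compound 1 to compound 4 (0.06 log units; within the scatter), so with the hydroxy group present, the chloro group leaves the two compounds within the scatter of each other.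

As far as these compounds go, whether the hydroxy group truly shifts the read-out stays open, as compound 2 and compound 3 have no number of their own. The compounds shown also leave open how an amine or a carboxylic acid at this position would read in this assay.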